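Adding a Bromophenylsulfonyl Group: Expectations for Compound 4

This account rests on a few compounds, and the source may have more. Where it says the series, first, only, none or still open, it means among the compounds named here.

Measured so far in a functional assay on SUP-B15 cells (Homo sapiens) for antiproliferative activity, with a stated time of 72 h; on this read-out lower numbers stand for an effect already at smaller amounts and higher numbers for an effect only at larger amounts of compound:
- Compound 1 `COc1ccc(-c2cc(=O)c3c(OC)cc(OC)cc3[nH]2)cc1` gives > 62000 nM, which is a limit of the assay and not a number.
- Compound 2 `COc1ccc(-c2cc(=O)c3c(OC)cc(OC)cc3n2S(=O)(=O)c2ccc(C=O)cc2)cc1` gives > 34400 nM, again a limit rather than a number.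
- Compound 3 `COc1ccc(-c2cc(=O)c3c(OC)cc(OC)cc3n2S(=O)(=O)c2ccc(C)c([N+](=O)[O-])c2)cc1` gives > 51700 nM, also a limit.

Compound 1 therefore stands only at a limit, and the two further values are limits as well, as the limit of > 62000 nM in this assay, at which 1 of the 3 values shown sits, the limit of > 34400 nM in this assay, at which 1 of the 3 values shown sits, and the limit of > 51700 nM in this assay, at which 1 of the 3 values shown sits, show. The step that the two limits leave unreadable from compound 1 to compound 2 cannot be read, and the step that the two limits leave unreadable from compound 2 to compound 3 cannot be read either. Compound 4 `COc1ccc(-c2cc(=O)c3c(OC)cc(OC)cc3n2S(=O)(=O)c2ccc(Br)cc2)cc1` differs from compound 1 by (4-bromophenyl)sulfonyl in place of hydrogen on an aromatic nitrogen. The measured steps that bear on this change, the attachment of a substituted phenylsulfonyl group on the same aromatic nitrogen, gave no readable size in this assay. No step beyond the scatter is therefore expected in this assay, in either direction, and the expected step is an at least 1.0-fold lower number from compound 1 to compound 4 (0.01 log units; that floor lies within the scatter). Compound 4 is estimated to give 60000 nM, between 20000 nM and 200000 nM, most likely again reported only as a limit.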

Compound 4, half-maximal effective concentration: 63800 nM
For compound 4 the middle estimate is 1.1-fold (0.03 log units) below the measured one; the range from low to high includes it.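

In this assay, among the compounds shown here, compound 4 gives a number, but compound 1, compound 2 and compound 3 stand only at limits, so no step to compound 4 can be read. The compounds shown leave open whether a substituted phenylsulfonyl group on the aromatic nitrogen changes the effect at all.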